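Working notes: from compound 3 to compound 4

A few compounds are considered here, and "the series" means these few. Any claim that something is new, unique, unknown or untested is made for them only; others in the source may bear on it.

Compound 1 `O=C1NCCc2ncccc21`: no result reported in an assay on isolated protein for inhibition of Nicotinamide N-methyltransferase (Homo sapiens), read by luminescence, with a stated time of 20 min; a higher number here means a weaker inhibitor, a lower number a stronger inhibitor.
Compound 2 `CCOc1cc(C)c(C(N)=O)cn1`: > 10000 nM, a limit of this assay.
Compound 3 `CNc1cc(C)c(C(N)=O)cn1`: 282 nM.

Among the compounds with values here, compound 3 holds the only single number in the set. Compound 2 sits at the assay limit (the limit of > 10000 nM in this assay, at which 1 of the 3 values shown sits). Compound 1 has no result. Within the data shown here, the one measured step, an at least 35-fold lower number from compound 2 to compound 3 (1.54 log units; beyond the scatter), concerns the methylamino group and not the carbon changed here. Compound 4 `CNc1cc(Cl)c(C(N)=O)cn1` differs from compound 3 by chloro in place of methyl on an aromatic carbon. Among the measured compounds shown here, no measured step bears on this change, so no step beyond the scatter is expected in this assay in either direction. Compound 4 is therefore estimated at 300 nM, with a range from 100 nM to 900 nM. This corresponds to an expected step of a 1.1-fold higher number from compound 3 to compound 4 (0.03 log units; within the scatter).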

Compound 4, half-maximal inhibitory concentration: 639 nM
The estimate for compound 4 lay 2.1-fold (0.33 log units) below the measured number; the measured number falls inside the stated range.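

In this assay the aromatic carbon opposite the ring nitrogen is sensitive to substitution: chloro in place of methyl gives a 2.3-fold higher number from compound 3 to compound 4 (0.36 log units; beyond the scatter), a modest step. Within the data shown here, this is the first reading at this carbon, since the earlier step concerned only the methylamino position, and here methyl gives the lower number of the two groups. No measured property on hand accounts for this step.

Open, on these data alone, is whether methoxy, fluoro or an amine on this carbon would give a lower number than methyl. Also open, as far as these compounds go, is whether the step from methyl to chloro would keep its size with a longer chain on the amino nitrogen.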